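The compounds below may be only part of what the source reports. "The series", "measured", "known", "first", "only" and "open" are said of these compounds alone.

Compound 1 `CC1=C(C(=O)Nc2ccc(Br)cc2)C(c2ccc(Cl)cc2Cl)N=C(SCc2ccccc2Cl)N1`: 24.6% in a functional assay on the whole organism (artery, strain albino) with Rattus norvegicus as the target, with a stated time of 600 min, at a dose of 10 mg/kg by the oral route; a higher number here means more inhibition at the dose given (going by the name of the read-out), a lower number less inhibition. Compound 2 `COc1ccc(C2N=C(SCc3ccccc3)NC(C)=C2C(=O)Nc2ccc(Br)cc2)cc1`: 11.3%.

Of the two compounds measured in this assay, compound 2 stands lowest, and compound 1 lies above it by more than the usual scatter. Compound 3 `COc1ccc(C2N=C(SCc3ccccc3Cl)NC(C)=C2C(=O)Nc2ccc(Br)cc2)cc1` differs from compound 2 by chloro in place of hydrogen on an aromatic carbon, the chloro entering on the benzyl group ortho to a large group. Among the measured compounds shown here, no measured pair shows this change on its own, so its size is unknown here. The expectation leans on compound 1, which carries the same (2-chlorobenzyl)sulfanyl group and gives 24.6%. Compound 3 is therefore expected to rise modestly, with the step of a number 6.7 percentage points higher from compound 2 to compound 3 (within the scatter) near the edge of the scatter. Compound 3 is estimated at 18%, between 6% and 32%.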

Compound 3, a percentage reported as inhibition, in the whole organism at one dose (the size of the read-out at that dose, not a potency): 13.3%
Compound 3: the middle estimate sits 4.7 percentage points above what was measured, and the stated range covers the measured number.
By their numbers in this assay, from the lowest: compounds 2 and 3 (each within the scatter of the next); then compound 1.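

Chloro in place of hydrogen on the benzyl group gives only a small change in this assay, with a number 2 percentage points higher from compound 2 to compound 3 (within the scatter) and no separation from compound 2. The change on the saturated ring carbon gives the larger step, with 4-methoxyphenyl in place of 2,4-dichlorophenyl giving a number 11.3 percentage points lower from compound 1 to compound 3 (beyond the scatter) and so tying the higher number of compound 1 to its 2,4-dichlorophenyl group rather than to its (2-chlorobenzyl)sulfanyl group. Nothing measured here explains either step. As far as these compounds go, whether a dimethylamino or carboxylic acid group on that aryl ring would shift the number remains open.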